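Replacing the bicyclic diamine with a methylpyrrolidine

The compounds below may be only part of what the source reports. "The series", "measured", "known", "first", "only" and "open" are said of these compounds alone.

Compound 2 `O=C(CCc1ccc(C(F)(F)F)cc1)Nc1ccc2nc(N3CC4CC3CN4)ccc2c1` gives the highest of the two numbers recorded so far: in a functional assay on HEK293 cells for activation of melanin-concentrating hormone receptor 1 (Rattus norvegicus), read by inositol phosphate accumulation (on this read-out lower numbers stand for an effect already at smaller amounts and higher numbers for an effect only at larger amounts of compound), compound 2 gives 490 nM, while compound 1 `O=C(CCc1ccc(C(F)(F)F)cc1)Nc1ccc2nc(N3CCC3)ccc2c1` gives 56 nM. For the measured compounds named here, the only step between measured compounds is an 8.8-fold higher number from compound 1 to compound 2 (0.94 log units; beyond the scatter), a change from the azetidine of compound 1 to the bicyclic diamine of compound 2. Compound 3 `CC1CCN(c2ccc3cc(NC(=O)CCc4ccc(C(F)(F)F)cc4)ccc3n2)C1` moves in the other direction: a group of 6 heavy atoms (5 carbon, 1 nitrogen; one five-membered non-aromatic ring with 1 hetero atom) in place of a group of 7 heavy atoms (5 carbon, 2 nitrogen; 2 five-membered non-aromatic rings with 1 hetero atom each), on an aromatic carbon, so the two fused five-membered rings with their hydrogen-bond donor give way to a single five-membered ring carrying a methyl group. Going by the values given here, no measured step covers this exact swap; the step from compound 1 to compound 2 shows that the bicyclic diamine sat at the higher number, and compound 3 returns to a single small saturated ring on the same aromatic carbon that compound 1 carried. The account therefore expects compound 3 to give a lower number than compound 2, by about a 5.4-fold lower number from compound 2 to compound 3 (0.74 log units; beyond the scatter). Compound 3 is estimated at 90 nM, within a range from 30 nM to 300 nM.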

Compound 3, half-maximal effective concentration: 400 nM
Compound 3: the middle estimate sits 4.4-fold (0.65 log units) below what was measured, outside the stated range (above it).
By their numbers in this assay, from the lowest: compound 1; then compounds 3 and 2 (each within the scatter of the next).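

Compound 3 drops the hydrogen-bond donor and one of the two rings of the group in compound 2, yet this assay shows a 1.2-fold lower number from compound 2 to compound 3 (0.09 log units; within the scatter), so on this aromatic carbon next to the ring nitrogen, the bicyclic diamine no longer stands apart from a single five-membered ring. The step of a 7.1-fold higher number from compound 1 to compound 3 (0.85 log units; beyond the scatter) shows that returning to one small saturated ring does not by itself restore the number of compound 1: 3-methylpyrrolidin-1-yl and the bicyclic diamine both sit beyond the scatter from azetidin-1-yl, which among these three compounds alone gives the lowest number. No measurement available here accounts for this outcome.

The compounds shown do not separate the contribution of the five-membered ring from that of its methyl group, a question that plain pyrrolidin-1-yl would address directly. On these data alone, how a six-membered piperidin-1-yl ring or an open-chain dimethylamino group would stand at this position also remains open, as does whether any group here could give a number lower than that of compound 1.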